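The source may hold more compounds than are shown below. What is called first, only, known or untested is meant among the compounds shown, and "the series" means these compounds.

In a functional assay on SMMC-7721 cells (Homo sapiens) for inhibition, read by MTT assay, with a stated time of 48 h (on this read-out higher numbers stand for weaker inhibition and lower numbers for stronger inhibition), compound 1 `Cc1cc2c(NCc3cccnc3N(C)S(C)(=O)=O)nc(Nc3ccc4c(c3)CC(=O)N4)nc2[nH]1` gives > 100000 nM as its result, and this is a limit of the assay, not a number. Among the measured compounds shown here, compound 2 `CN(c1ncccc1CNc1nc(Nc2ccc(F)cc2)nc2[nH]cc(F)c12)S(C)(=O)=O` gives 27900 nM in this assay and so holds the only true number so far, a single reference point with no other measured number to compare it with.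

Compound 3 `CN(c1ncccc1CNc1nc(Nc2cccc(CN)c2)nc2[nH]cc(F)c12)S(C)(=O)=O` is compound 2 with one group exchanged: 3-(aminomethyl)phenyl in place of 4-fluorophenyl on a nitrogen on an aromatic ring. In words, 3-(aminomethyl)phenyl stands in place of 4-fluorophenyl on a nitrogen on an aromatic ring, and the rest of the molecule stays the same.

For the measured compounds named here, no measured pair shows what this exchange does, so the forecast starts from compound 2 at 27900 nM alone and has to stay wide. A modest shift is the cautious expectation, not a dramatic one. The estimated change a 2.3-fold lower number from compound 2 to compound 3 (0.37 log units; beyond the scatter) is a small move towards stronger inhibition, only slightly beyond the usual scatter of repeated measurements. Compound 3 is expected to come in near 12000 nM in this assay, with an estimated range from 2500 nM to 60000 nM as the likely span of the result.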

Compound 3, half-maximal inhibitory concentration: > 100000 nM
Compound 3 was reported as a limit (the forecaster's own chance of this, stated with the estimate: 15%); at least 8.3-fold (0.92 log units) between middle value and limit.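

On a nitrogen on an aromatic ring, exchanging 4-fluorophenyl for 3-(aminomethyl)phenyl provides the only one-place comparison shown in this assay: an at least 3.5-fold higher number from compound 2 to compound 3 (0.55 log units; beyond the scatter), a shift towards weaker inhibition that lies beyond the usual scatter. The result for compound 3, > 100000 nM, is a limit of the assay and not a number. The group on this nitrogen therefore matters to the read-out, and this exchange does not bring stronger inhibition, but the full size of the step stays unknown because the result for compound 3 is a limit: the limit of > 100000 nM in this assay, at which 2 of the 3 values shown sit.

The two groups differ both in what they carry, a fluorine or an aminomethyl group, and in the numbering of that substituent on the ring, so these compounds cannot show which of the two differences matters. From the compounds shown here alone, it also stays open whether a plain phenyl, or a phenyl carrying a methoxy group or a carboxylic acid, would leave the value of compound 2 unchanged, weaken inhibition further or strengthen it.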